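The source may hold more compounds than are shown below. What is called first, only, known or untested is meant among the compounds shown, and "the series" means these compounds.

Working notes on the series. The shared core of compound 1 `COc1ccc(-c2cc3ccccc3nc2/C=C/C(=O)c2ccc(OC)c(OC)c2)cc1` carries a variable group on a carbonyl carbon, and this is the position varied throughout. Going by the values given here, in a functional assay on NCI-H1299 cells (Homo sapiens) for antiproliferative activity, read by XTT assay, with a stated time of 72 h (a higher number here means a weaker inhibitor, a lower number a stronger inhibitor), compound 1 gives 1050 nM, the second highest of the three numbers measured so far. Compound 2 `COc1ccc(-c2cc3ccccc3nc2/C=C/C(=O)c2ccc(N)cc2)cc1` gives 6510 nM in this assay, and compound 3 `COc1ccc(-c2cc3ccccc3nc2/C=C/C(=O)c2cccs2)cc1` gives 720 nM. The measured steps are a 6.2-fold higher number from compound 1 to compound 2 (0.79 log units; beyond the scatter), a 1.5-fold lower number from compound 1 to compound 3 (0.16 log units; within the scatter) and a 9.0-fold lower number from compound 2 to compound 3 (0.96 log units; beyond the scatter).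

Compound 4 `COc1ccc(-c2cc3ccccc3nc2/C=C/C(=O)c2ccsc2)cc1` differs from compound 1 by thiophen-3-yl in place of 3,4-dimethoxyphenyl on a carbonyl carbon. Among the compounds with values here, the step that bears on this change is the one from compound 1 to compound 3, where the same 3,4-dimethoxyphenyl gave way to a thiophen-2-yl on the same carbonyl carbon and the number stayed within the scatter. The exchange for thiophen-3-yl is of the same kind, with only the point of attachment on the five-membered ring differing. No step beyond the scatter is therefore expected; the estimate for compound 4 means a 1.2-fold lower number from compound 1 to compound 4 (0.09 log units; within the scatter). For compound 4 the expected value in this assay is 850 nM, with a range from 300 nM to 2500 nM.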

Compound 4, half-maximal inhibitory concentration: 1220 nM
The estimate for compound 4 lay 1.4-fold (0.16 log units) below the measured number, within the range that was stated.
By their numbers in this assay, from the lowest: compounds 3, 1 and 4 (each within the scatter of the next); then compound 2.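

In this assay, the point of attachment on the thiophene ring leaves no step beyond the scatter (a 1.7-fold higher number from compound 3 to compound 4 (0.23 log units; within the scatter)), so thiophen-2-yl and thiophen-3-yl cannot be told apart on this carbonyl carbon. Thiophen-3-yl, with 5 heavy atoms, also stays within the scatter of the 10-atom 3,4-dimethoxyphenyl (a 1.2-fold higher number from compound 1 to compound 4 (0.07 log units; within the scatter)), while the step from 4-aminophenyl lies beyond it (a 5.3-fold lower number from compound 2 to compound 4 (0.73 log units; beyond the scatter)), so among the four compounds only compound 2 stands apart. Nothing available explains this grouping.

On these data alone, it remains open whether the amine itself sets compound 2 apart or whether the whole 4-aminophenyl group does. Also open, as far as these compounds go, is how a plain phenyl, a furan-2-yl or a pyridin-3-yl group would stand on this carbonyl carbon.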